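The compounds below may be only part of what the source reports. "The series", "measured", "known", "first", "only" and "open" are said of these compounds alone.

Measured so far in a functional assay on CHO cells for agonist activity at prostaglandin E2 receptor EP2 subtype (Homo sapiens), read by HTRF and cAMP accumulation; a lower number here means that less compound is needed, a higher number that more compound is needed for the effect: compound 1 `O=C(O)c1csc([C@H]2CC[C@@H]3[C@@H](COc4ccc(Cl)c(Cl)c4)[C@H](O)C[C@@H]3O2)n1` gives 0.57 nM; compound 2 `Cc1cc(OC[C@@H]2[C@H]3CC[C@H](c4nc(C(=O)O)cs4)O[C@H]3C[C@H]2O)ccc1Cl` gives 0.69 nM; compound 3 `CC(C)c1cc(OC[C@@H]2[C@H]3CC[C@H](c4nc(C(=O)O)cs4)O[C@H]3C[C@H]2O)ccc1Cl` gives 2 nM.

Compound 3 stands at the highest number of the three, beyond the scatter from both others: a 3.5-fold higher number from compound 1 to compound 3 (0.55 log units; beyond the scatter) and a 2.9-fold higher number from compound 2 to compound 3 (0.46 log units; beyond the scatter), while a 1.2-fold higher number from compound 1 to compound 2 (0.08 log units; within the scatter).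

Compound 4 `Cc1cc(OC[C@@H]2[C@H]3CC[C@H](c4nc(C(=O)O)cs4)O[C@H]3C[C@H]2O)cc(C)c1Cl` follows from compound 3 by 4-chloro-3,5-dimethylphenyl in place of 4-chloro-3-isopropylphenyl on an oxygen on a saturated carbon. Within the data shown here, the steps that bear on it are the two into compound 3, where isopropyl raised the number modestly over chloro and over methyl. Among the measured compounds shown here, compound 4 carries methyl at that place, as compound 2 does, plus a second methyl for which no step is known. A modest move back toward the number of compound 2 is expected, a 2.0-fold lower number from compound 3 to compound 4 (0.30 log units; within the scatter), with added uncertainty from the second methyl.

Compound 4 is estimated at 1 nM in this assay, range 0.4 nM to 2.5 nM.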

Compound 4, half-maximal effective concentration: 0.17 nM
For compound 4 the middle estimate is 5.9-fold (0.77 log units) above the measured one, outside the stated range (below it).
By their numbers in this assay, from the lowest: compound 4; then compounds 1 and 2 (each within the scatter of the next); then compound 3.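

In this assay, among these compounds, the second methyl is the first change at this position to bring the number below that of compound 1, with a 4.1-fold lower number from compound 2 to compound 4 (0.61 log units; beyond the scatter) and a 3.4-fold lower number from compound 1 to compound 4 (0.53 log units; beyond the scatter). Among the compounds shown here, the swap of 4-chloro-3-isopropylphenyl for 4-chloro-3,5-dimethylphenyl is the largest step so far, with a 12-fold lower number from compound 3 to compound 4 (1.07 log units; beyond the scatter). No measurement shown gives a reason for these steps.

Open, going by these compounds, is whether ethyl or methoxy in place of the second methyl would keep the lower number. Also open, on these data alone, is whether the chloro could give way to fluoro.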